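Methyl for hydrogen at the far ring edge

This account rests on a few compounds, and the source may have more. Where it says the series, first, only, none or still open, it means among the compounds named here.

Compound 1 `COc1ccc(-c2cc(Cl)cc(Cl)c2/C=C/[C@@H]2C[C@@H](O)CC(=O)O2)cc1` gives 470 nM in an assay for inhibition of 3-hydroxy-3-methylglutaryl-coenzyme A reductase (Rattus norvegicus); on this read-out lower numbers stand for stronger inhibition and higher numbers for weaker inhibition. Compound 2 `O=C1C[C@H](O)C[C@@H](/C=C/c2c(Cl)cc(Cl)cc2-c2ccccc2)O1` gives 80 nM in this assay.

For the measured compounds named here, compound 2 carries the lowest of the two numbers seen so far; the only neighbour, compound 1, sits higher by a step of a 5.9-fold lower number from compound 1 to compound 2 (0.77 log units; beyond the scatter), which removes a methoxy from an aromatic carbon and leaves a plain hydrogen there. Compound 3 `Cc1ccc(-c2cc(Cl)cc(Cl)c2/C=C/[C@@H]2C[C@@H](O)CC(=O)O2)cc1` is not yet measured. It differs from compound 2 by methyl in place of hydrogen on an aromatic carbon — a single carbon, on an aromatic carbon of a six-membered aromatic ring of carbon only, para to a large group. Going by the values given here, the one measured step bears directly on this position: putting a methoxy there, read from compound 2 back to compound 1, raised the number beyond the scatter. A methyl is smaller than a methoxy and carries no hydrogen-bond acceptor, so a weaker version of that rise is expected, a modest upward step of a 2.0-fold higher number from compound 2 to compound 3 (0.30 log units; within the scatter). The estimate for compound 3 in this assay is therefore 160 nM, with a range from 60 nM to 420 nM.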

Compound 3, half-maximal inhibitory concentration: 190 nM
Compound 3: middle estimate off by 1.2-fold (0.07 log units), on the low side; measured number inside the range.
By their numbers in this assay, from the lowest: compound 2; then compound 3; then compound 1.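

Even a single carbon at this position, para to a large group, raises the number beyond the scatter in this assay (a 2.4-fold higher number from compound 2 to compound 3 (0.38 log units; beyond the scatter)), so the rise seen earlier does not require a methoxy. The new compound also allows methyl and methoxy to be compared directly at the same carbon, and that step too lies beyond the scatter (a 2.5-fold lower number from compound 1 to compound 3 (0.39 log units; beyond the scatter)), which places the three compounds in a clear order: hydrogen gives the lowest number, methyl an intermediate one and methoxy the highest. Nothing presented here accounts for this order, and the numbers alone cannot say why either group weakens inhibition compared with hydrogen.

As far as these compounds go, only hydrogen, methyl and methoxy have been compared at this one carbon, so it remains open whether any group could bring the number below that of hydrogen, and a fluorine, a chlorine, a hydroxyl or an amine would each test this. A longer chain such as ethyl would show whether the number keeps rising as the carbon group grows beyond methyl.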